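A few compounds are considered here, and "the series" means these few. Any claim that something is new, unique, unknown or untested is made for them only; others in the source may bear on it.

Measured so far:
compound 1 `O=C(NCc1ccc(F)cc1)c1nc(Br)c2cccnc2c1NCc1ccccc1` — "not determined" (no result reported) in a functional assay on MCF7 cells (Homo sapiens) for cytotoxicity, read by MTT assay, with a stated time of 72 h; a lower number here means a stronger inhibitor, a higher number a weaker inhibitor
compound 2 `CS(=O)(=O)Oc1c(C(=O)NCc2ccc(F)cc2)nc(Br)c2cccnc12` — "not determined" (no result reported) in this assay
compound 3 `Nc1ccc(Nc2c(C(=O)NCc3ccc(F)cc3)nc(Br)c3cccnc23)cc1` — 4000 nM in this assay

Compound 1 has no single number in this assay; compound 2 likewise has none, so only compound 3 anchors the series. Compound 4 `O=C(NCCCNc1c(C(=O)NCc2ccc(F)cc2)nc(Br)c2cccnc12)c1ccccc1` differs from compound 1 by 2-benzamidoethyl in place of phenyl on a saturated chain carbon bound to a nitrogen on an aromatic ring. Among the compounds with values here, no step between measured compounds exists, and the change to compound 4 has no measured counterpart. In this assay the step from compound 1 to compound 4 is expected to be small, with no clear direction beyond the scatter. Within the data shown here, compound 4 is expected to give about 5000 nM in this assay, within 1500 nM to 16000 nM, close to the single anchor given by compound 3.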

Compound 4, half-maximal inhibitory concentration: 2000 nM
The estimate for compound 4 lay 2.5-fold (0.40 log units) above the measured number; measured number inside the range.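

Within the data shown here, compound 1 has no single number, so no step from it to compound 4 can be read. On these data alone, whether 2-benzamidoethyl in place of phenyl changes cytotoxicity stays open. No measured evidence bears on this result.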